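This account rests on a few compounds, and the source may have more. Where it says the series, first, only, none or still open, it means among the compounds named here.

Of the compounds shown here, three sharing one core have been tested in a functional assay on the whole organism for inhibition, with Rattus norvegicus as the target, read by paw edema, with a stated time of 4 h, at a dose of 50 mg/kg; a lower number here means less inhibition, a higher number more inhibition at the dose given (going by the name of the read-out). Compound 1 `CC(=O)c1c(NNc2ccc(C)cc2)cc(C)oc1=O` gives 50%, compound 2 `CC(=O)c1c(NNc2ccc(Cl)cc2)cc(C)oc1=O` gives 28.4%, and compound 3 `COc1ccc(NNc2cc(C)oc(=O)c2C(C)=O)cc1` gives 24.5%, the lowest number of the three, though its gap to compound 2 is within the scatter. Both replacements of the methyl lowered inhibition, a number 21.6 percentage points lower from compound 1 to compound 2 (beyond the scatter) and a number 25.5 percentage points lower from compound 1 to compound 3 (beyond the scatter), while a number 3.9 percentage points lower from compound 2 to compound 3 (within the scatter). Compound 4 `CC(=O)c1c(NNc2ccc([N+](=O)[O-])cc2)cc(C)oc1=O` is not yet measured; it differs from compound 3 by nitro in place of methoxy on an aromatic carbon. Among the compounds with values here, no measured step exchanges methoxy for nitro, so the nearest guide is that compounds 2 and 3, carrying the two groups other than methyl, sit close together. The step is therefore expected to be a number 2.5 percentage points higher from compound 3 to compound 4 (within the scatter), within the scatter. Compound 4 is estimated at 27%, with a range from 12% to 42%.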

Compound 4, a percentage reported as inhibition, in the whole organism at one dose (the size of the read-out at that dose, not a potency): 44.1%
Beside the measured number, compound 4's estimate is 17.1 percentage points below it; the measured number lies above the stated range.
By their numbers in this assay, from the lowest: compounds 3 and 2 (each within the scatter of the next); then compounds 4 and 1 (each within the scatter of the next).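

At this position, on an aromatic carbon para to a large group, replacing methyl does not always lower the number in this assay. Nitro gives a number 19.6 percentage points higher from compound 3 to compound 4 (beyond the scatter) and a number 15.7 percentage points higher from compound 2 to compound 4 (beyond the scatter), while its step from methyl is a number 5.9 percentage points lower from compound 1 to compound 4 (within the scatter). The drop seen with chloro and methoxy is therefore not shared by every replacement, and nothing measured here explains the difference. Going by these compounds, whether an amine, a carboxylic acid or a longer chain at this position would group with methyl and nitro or with chloro and methoxy stays open.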